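Moving the methoxy group on a carbon-only aromatic ring

The compounds below may be only part of what the source reports. "The series", "measured", "known", "first", "only" and "open" are said of these compounds alone.

Compound 1 `CC[C@@H](Nc1c(C#N)c(-c2ccc(-c3cccc(OC)c3)cc2)nc2cnccc12)C(N)=O` was measured in a physicochemical assay for lipophilicity, read by HPLC, at pH 7.5 (a higher number here means a more lipophilic compound, a lower number a more polar compound), where compound 1 gives 2.7. That is the lower of the two numbers recorded so far. The other measured compound, compound 2 `CCOc1ccccc1-c1ccc(-c2nc3cnccc3c(NC(CC)CNS(=O)(=O)C3CC3)c2C#N)cc1`, gives 3.6 in this assay, a value that lies beyond the scatter above that of compound 1; these two compounds differ in several places at once, so nothing further can be read from that gap.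

The unmeasured compound 3 `CC[C@@H](Nc1c(C#N)c(-c2ccc(-c3ccc(OC)cc3)cc2)nc2cnccc12)C(N)=O` keeps the shared core and side chain of compound 1 and changes only the six-membered aromatic ring of carbon only: 4-methoxyphenyl in place of 3-methoxyphenyl on an aromatic carbon. The same atoms are present, joined differently. A change of this kind, with no group added or removed, gives no ground to expect a shift in this assay beyond the scatter in either direction. The expected step is therefore small: a number 0.10 log units higher from compound 1 to compound 3 (within the scatter). For compound 3 the estimate in this assay is 2.8, within a range from 2.5 to 3.1.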

Compound 3, distribution coefficient: 2.7
Compound 3: the middle estimate sits 0.10 log units above what was measured; the measured number falls inside the stated range.
By their numbers in this assay, from the lowest: compounds 1 and 3 (each within the scatter of the next); then compound 2.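

Moving the methoxy group gives the first comparison here in which only one place differs: in this assay, the step is no change at the digits printed from compound 1 to compound 3 (within the scatter) for 4-methoxyphenyl in place of 3-methoxyphenyl on an aromatic carbon. With the shared core and side chain held constant, this shows that the rearrangement, which ends para to a large group, leaves the read-out within the scatter, something the gap between compound 1 and compound 2 could not show, as those two differ in several places at once. Nothing measured here explains why the number holds at this place.

The compounds shown leave open whether the read-out would stay as steady if a carboxylic acid or a primary amine took the place of the methoxy group on this ring, where atoms would change rather than only being joined differently. Among these compounds, they also leave open whether moving the methoxy group would give the same step on a compound carrying the side chain of compound 2 instead of the one shared by compound 1 and compound 3.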